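A Methyl for a Hydrogen on an Aromatic Nitrogen

The compounds below may be only part of what the source reports. "The series", "measured", "known", "first", "only" and "open" are said of these compounds alone.

Of the compounds shown here, three have been measured in a functional assay on PC-3 cells (Homo sapiens) for cytotoxicity, read by MTT assay, with a stated time of 72 h; a higher number here means a weaker inhibitor, a lower number a stronger inhibitor. Compound 1 `Cn1nc(-c2ccccc2)c2cc(C(=N)Nc3ccccc3)ncc21` gives 17300 nM in this assay. Compound 2 `N=C(Nc1ccccc1)c1cc2c(-c3ccccc3)n[nH]c2cn1` gives 23000 nM in this assay. The step between them, a 1.3-fold lower number from compound 2 to compound 1 (0.12 log units; within the scatter), comes from the change (methyl in place of hydrogen on an aromatic nitrogen).

Compound 3 `N=C(Nc1cccc(C(F)(F)F)c1)c1cc2cn[nH]c2cn1` is built on a different core, and how the two cores differ is not broken down here. In this assay compound 3 gives only a limit of the assay, > 50000 nM. That limit is the limit of > 50000 nM in this assay, at which 1 of the 3 values shown sits.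

Compound 4 `Cn1ncc2cc(C(=N)Nc3cccc(C(F)(F)F)c3)ncc21` has not yet been measured in this assay. It differs from compound 3 by methyl in place of hydrogen on an aromatic nitrogen. Going by the values given here, this is the same kind of change as the one from compound 2 to compound 1, but not the same change: in the pair of compound 2 and compound 1 the place is also two ring bonds from the ring atom that bears a phenyl group, whereas the core of compound 3 and compound 4 carries no phenyl group there.

The step from compound 3 to compound 4 is expected to be small, a step that the limit leaves unreadable from compound 3 to compound 4, because a 1.3-fold lower number from compound 2 to compound 1 (0.12 log units; within the scatter) lies within the scatter. Since compound 3 itself gives only a limit, the result for compound 4 may well again be a limit rather than a number. For compound 4 the expected value in this assay is 60000 nM, with a likely range from 25000 nM to 150000 nM.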

Compound 4, half-maximal inhibitory concentration: 50000 nM
For compound 4 the middle estimate is 1.2-fold (0.08 log units) above the measured one; the range from low to high includes it.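

In this assay the entry for compound 3 is a limit of the assay and not a number, so the size of the step to compound 4 cannot be read: the limit of > 50000 nM in this assay, at which 1 of the 4 values shown sits.

Set beside the earlier step, the methyl in place of hydrogen on an aromatic nitrogen (a number no higher from compound 3 to compound 4 (the limit leaves the size open)) therefore gives no firm comparison between the two cores: the same change on two cores in this assay, a 1.3-fold lower number (0.12 log units; within the scatter) from compound 2 to compound 1 and a number no higher (the limit leaves the size open) from compound 3 to compound 4; the limit leaves it open whether they differ

Compound 4 gives 50000 nM, which is compatible with the small step on the core of compound 1 carrying over to the core of compound 3, but it does not show that the change has the same size on both cores, or that it has any effect at all on the second one.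

The compounds shown leave open whether a different group on that aromatic nitrogen, such as an ethyl group or a longer chain ending in an amine, would shift the number beyond the scatter on either core. They also leave open how the methyl change would read on a compound that carries both the phenyl group and the trifluoromethyl group, or one that has a carboxylic acid in place of the trifluoromethyl group.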